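Heteroaryl swaps on the amide nitrogen of the shared core

The compounds below may be only part of what the source reports. "The series", "measured", "known", "first", "only" and "open" are said of these compounds alone.

Measured compounds:
compound 1 `CCCOc1cc(C)c2c(c1C)CC(C(C)C(=O)NCc1cccs1)CC2`: 3000 nM
compound 2 `CCCOc1cc(C)c2c(c1C)CC(C(C)C(=O)Nc1ccccn1)CC2`: 6000 nM

In an assay for inhibition of Polyunsaturated fatty acid 5-lipoxygenase (Homo sapiens) (on this read-out lower numbers stand for stronger inhibition and higher numbers for weaker inhibition), compound 1 gives 3000 nM and compound 2 gives 6000 nM. For the measured compounds named here, the only step known, a 2.0-fold higher number from compound 1 to compound 2 (0.30 log units; within the scatter), lies within the scatter, so the two numbers cannot be ranked against each other. Compound 3 `CCCOc1cc(C)c2c(c1C)CC(C(C)C(=O)Nc1nccs1)CC2` carries 1,3-thiazol-2-yl in place of pyridin-2-yl on an amide-type nitrogen. Going by the values given here, the one step that bears on such a swap at this nitrogen is a 2.0-fold higher number from compound 1 to compound 2 (0.30 log units; within the scatter), and it did not leave the scatter. No step beyond the scatter is therefore expected in this assay, no change at the digits printed from compound 2 to compound 3 (within the scatter). Compound 3 is estimated at 6000 nM, within 2000 nM to 18000 nM.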

Compound 3, half-maximal inhibitory concentration: 1000 nM
For compound 3 the middle estimate is 6.0-fold (0.78 log units) above the measured one, and the stated range ends above it.
By their numbers in this assay, from the lowest: compound 3; then compounds 1 and 2 (each within the scatter of the next).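

For the compounds shown here, at the amide-type nitrogen, the identity of the heteroaryl group can shift this read-out: 1,3-thiazol-2-yl in place of pyridin-2-yl gives a 6.0-fold lower number from compound 2 to compound 3 (0.78 log units; beyond the scatter), the first step beyond the scatter. The same group also separates from (thiophen-2-yl)methyl, with a 3.0-fold lower number from compound 1 to compound 3 (0.48 log units; beyond the scatter), which places compound 3 lowest of the three. As far as these compounds go, whether a 1,3-oxazol-2-yl group, or a methyl or carboxylic acid on the 1,3-thiazol-2-yl ring, would keep the lower number remains open. No supporting data explain either step.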